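From Fluoro to Isopropyl: an Expected Flat Step

The source may hold more compounds than are shown below. What is called first, only, known or untested is meant among the compounds shown, and "the series" means these compounds.

Compound 1, `O=C(/C=C/c1ccc(F)cc1)c1cccc(NC(=O)c2cc(-c3ccncc3)n[nH]2)c1`, 56000 nM
Compound 2, `COc1ccc(/C=C/C(=O)c2cccc(NC(=O)c3cc(-c4ccncc4)n[nH]3)c2)cc1`, 38400 nM
Compound 3, `CN(C)c1ccc(/C=C/C(=O)c2cccc(NC(=O)c3cc(-c4ccncc4)n[nH]3)c2)cc1`, 41900 nM

Of the compounds shown here, three sharing one core have been measured in a functional assay, read by spectrophotometry, tested at 100 uM; a lower number here means a stronger inhibitor, a higher number a weaker inhibitor. Compound 1 gives the highest of the three numbers, yet its distance to either of the others is within the scatter: the step of a 1.5-fold lower number from compound 1 to compound 2 (0.16 log units; within the scatter) and the step of a 1.3-fold lower number from compound 1 to compound 3 (0.13 log units; within the scatter) are both small, and the step of a 1.1-fold higher number from compound 2 to compound 3 (0.04 log units; within the scatter) is smaller still. So far, changing the group on the aromatic carbon has not moved the read-out beyond what repeated measurement would show.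

Compound 4, `CC(C)c1ccc(/C=C/C(=O)c2cccc(NC(=O)c3cc(-c4ccncc4)n[nH]3)c2)cc1`, has not been measured. It differs from compound 1 as follows: isopropyl in place of fluoro on an aromatic carbon. The two measured steps that bear on this change, from compound 1 to compound 2 and from compound 1 to compound 3, both replaced the same fluoro with another group and both stayed within the scatter. On that basis compound 4 is expected to show no step beyond the scatter, in either direction, with the estimated step of a 1.2-fold lower number from compound 1 to compound 4 (0.09 log units; within the scatter). The estimate for compound 4 is therefore 45000 nM, with a range from 20000 nM to 100000 nM.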

Compound 4, half-maximal inhibitory concentration: 52300 nM
For compound 4 the middle estimate is 1.2-fold (0.07 log units) below the measured one; the range from low to high includes it.
By their numbers in this assay, from the lowest: compounds 2, 3, 4 and 1 (each within the scatter of the next).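

In this assay the change to isopropyl, which brings in three carbon atoms and no other element, stays within the scatter (a 1.1-fold lower number from compound 1 to compound 4 (0.03 log units; within the scatter)). The earlier replacements of fluoro each brought in oxygen or nitrogen, so this result extends the flat picture at this position to an all-carbon branched group. Isopropyl also stays within the scatter of dimethylamino (a 1.2-fold higher number from compound 3 to compound 4 (0.10 log units; within the scatter)) and of methoxy (a 1.4-fold higher number from compound 2 to compound 4 (0.13 log units; within the scatter)), so none of the four groups stands apart from the others, and no measurement shown offers an explanation for this flatness.

Going by these compounds, whether a carboxylic acid, a primary amine or a longer alkyl chain on this aromatic carbon would produce a step beyond the scatter remains open. So does whether changes elsewhere on the shared core would move the read-out further than any group at this position has.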